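A few compounds are considered here, and "the series" means these few. Any claim that something is new, unique, unknown or untested is made for them only; others in the source may bear on it.

Measured compounds:
- compound 1, `CC1(C)CCOc2ccc(NC(=S)Nc3ccc(C(F)(F)F)cc3)cc21`: 28%
- compound 2, `CC1(C)CC(C)(C)c2cc(NC(=S)Nc3ccc([N+](=O)[O-])cc3)ccc2S1`: 84.3%
- compound 3, `CCC1(CC)CC(C)(C)c2cc(NC(=O)Nc3ccc([N+](=O)[O-])cc3)ccc2O1`: 93.2%

All three were tested in a functional assay on A2780 cells (Homo sapiens) for inhibition, with a stated time of 72 h, tested at 10 uM; on this read-out higher numbers stand for more inhibition of growth at the one concentration tested and lower numbers for less inhibition of growth. Among these three numbers, compound 1 stands lowest. Its nearest neighbour is compound 2, whose number lies well beyond the usual scatter above it, and compound 3 lies further still. Compounds 2 and 3 differ from compound 1 in more than one place, so their numbers alone do not single out what drives the gap.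

Compound 4, `CC1(C)CCOc2ccc(NC(=S)Nc3ccc([N+](=O)[O-])cc3)cc21`, is not yet measured in this assay. It differs from compound 1 in exactly one place: nitro in place of trifluoromethyl on an aromatic carbon. The two compounds that carry a nitro group, compound 2 with 84.3% and compound 3 with 93.2%, both sit far above compound 1, but they also differ elsewhere, so the change cannot be attributed to the nitro group alone.

For compound 4 the expectation is a rise beyond the scatter, a number 32 percentage points higher from compound 1 to compound 4 (beyond the scatter), resting on the higher numbers of compound 2 and compound 3. The estimated value for compound 4 is 60%, in a range from 30% to 90%.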

Compound 4, percent growth inhibition at one concentration: 19%
Compound 4: middle estimate off by 41 percentage points, on the high side, and the stated range ends above it.
By their numbers in this assay, from the lowest: compounds 4 and 1 (each within the scatter of the next); then compounds 2 and 3 (each within the scatter of the next).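

Putting nitro in place of trifluoromethyl on this aromatic carbon, para to a large group, gives a number 9 percentage points lower from compound 1 to compound 4 (within the scatter) in this assay. For the compounds shown here, this is the first comparison in which only this one group changes, and on the core of compound 1 the two groups cannot be told apart by this read-out, so nitro alone does not bring a high number on this core. No measurement at hand offers a reason for this result.

On these data alone, it stays open whether the same change would also make no clear difference on a different core, since this single pair speaks only for the core of compound 1. Also open, as far as these compounds go, is what another group on this carbon, such as an amine or a carboxylic acid, would give.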